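Hydroxy for methoxy: stepping from compound 2 to compound 4

A few compounds are considered here, and "the series" means these few. Any claim that something is new, unique, unknown or untested is made for them only; others in the source may bear on it.

Going by the values given here, compound 2 `COc1cc(-c2nn(-c3cccc(NC(=O)Nc4cc(C(F)(F)F)cc(C(F)(F)F)c4)c3)cc2-c2ccncc2)ccc1Cl` is one of three compounds so far seen in a functional assay on K562 cells (Homo sapiens) for inhibition, read by sulforhodamine B assay, with a stated time of 48 h (a lower number here means that less compound is tolerated, a higher number that more compound is tolerated), and all three returned limits rather than numbers. In this assay compound 2 gives > 50000 nM, which is a limit of the assay. Compound 3 `COc1cc(-c2nn(-c3cccc(NC(=O)Nc4cccc(C(F)(F)F)c4)c3)cc2-c2ccncc2)ccc1Cl` gives > 50000 nM, also a limit. Compound 1 `O=C(Nc1cccc(-n2cc(-c3ccncc3)c(-c3ccc(Cl)c(O)c3)n2)c1)Nc1cccc(C(F)(F)F)c1` gives > 32500 nM, again a limit. Compound 2 thus stands among the values at the limit of > 50000 nM in this assay, at which 2 of the 3 values shown sit, while compound 1 sits at the limit of > 32500 nM in this assay, at which 1 of the 3 values shown sits.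

Compound 4 `O=C(Nc1cccc(-n2cc(-c3ccncc3)c(-c3ccc(Cl)c(O)c3)n2)c1)Nc1cc(C(F)(F)F)cc(C(F)(F)F)c1` arises from compound 2 by hydrogen in place of methyl on an oxygen on an aromatic ring, methoxy to hydroxy, 4-chloro-3-methoxyphenyl to 4-chloro-3-hydroxyphenyl. The reverse of this change has been measured once, as a step that the two limits leave unreadable from compound 1 to compound 3; the neighbouring step that the two limits leave unreadable from compound 2 to compound 3 is equally unreadable. Neither step yields a direction or a size, so nothing beyond another value at a limit is anticipated for compound 4 in this assay. The estimate for compound 4 in this assay is 50000 nM, with a range from 20000 nM to 120000 nM. The step this estimate implies, a number no higher from compound 2 to compound 4 (the limit leaves the size open), is expected to amount to no change beyond the scatter.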

Compound 4, concentration lethal to 50% of the cells: > 50000 nM
Compound 4 ended at the assay's limit (the forecaster's own chance of this, stated with the estimate: 85%); the middle value sits exactly at the limit.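

The steps from compound 2 to compound 4 and from compound 1 to compound 4 cannot be read, as each pair has limits at both ends. The compounds shown leave open whether methoxy to hydroxy, or the second trifluoromethyl, shifts the value at all.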